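Exchanging the urea aryl group for isopropyl in a sterol O-acyltransferase series

The source may hold more compounds than are shown below. What is called first, only, known or untested is meant among the compounds shown, and "the series" means these compounds.

Three ureas share a heptyl chain, a five-carbon linker to a sulfur-bound heteroaryl, and a 2,4-difluorophenyl on the amide nitrogen. In an assay on microsomes from liver for inhibition of sterol O-acyltransferase 1 (Rattus norvegicus) (a lower number here means a stronger inhibitor, a higher number a weaker inhibitor), compound 1 `CCCCCCCN(CCCCCSc1nc(O)c2ccccc2n1)C(=O)Nc1ccc(F)cc1F` gives 4000 nM, compound 2 `CCCCCCCN(CCCCCSc1ncccn1)C(=O)Nc1ccc(F)cc1F` gives 3300 nM, and compound 3 `CCCCCCCN(CCCCCSc1nc(N)c2c[nH]nc2n1)C(=O)Nc1ccc(F)cc1F` gives 4230 nM. Compound 3 holds the highest number, yet every gap is within the scatter: a 1.2-fold lower number from compound 1 to compound 2 (0.08 log units; within the scatter), a 1.1-fold higher number from compound 1 to compound 3 (0.02 log units; within the scatter), a 1.3-fold higher number from compound 2 to compound 3 (0.11 log units; within the scatter). Compound 4 `CCCCCCCN(CCCCCSc1nc(N)c2c[nH]nc2n1)C(=O)NC(C)C` differs by isopropyl in place of 2,4-difluorophenyl on an amide-type nitrogen. All measured steps alter only the sulfur-bound group and leave the urea untouched, so none speaks to this change; the data give no guidance on the amide side. An expected step of a 1.9-fold higher number from compound 3 to compound 4 (0.28 log units; within the scatter) in this assay is therefore a guess. Compound 4 is estimated at 8000 nM, within 2000 nM to 30000 nM.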

Compound 4, half-maximal inhibitory concentration: "not active" (no number reported)
Compound 4 has no reported number here, and the estimate cannot be compared.
By their numbers in this assay, from the lowest: compounds 2, 1 and 3 (each within the scatter of the next).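

For the compounds shown here, compound 4 carries only the note "not active" in this assay, with no number, and no step from compound 3 to compound 4 can be read. No evidence shown bears on this result. The compounds shown leave open how isopropyl and 2,4-difluorophenyl on the urea compare.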